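Methylation of a phenol on an inactive triazole series

The source may hold more compounds than are shown below. What is called first, only, known or untested is meant among the compounds shown, and "the series" means these compounds.

Working notes on a set of diaryl triazoles tested in a functional assay on MDA-MB-231 cells (Homo sapiens) for cytotoxicity, read by MTT assay; on this read-out higher numbers stand for weaker inhibition and lower numbers for stronger inhibition. Compound 1 `COc1ccc(-c2cn(-c3ccc(OC)cc3OC)nn2)cc1` carries three methoxy groups. In this assay compound 1 gives > 10000 nM, a limit of the assay rather than a number. Compound 3 `COc1cc(OC)cc(-c2cn(-c3ccc(OC)c(OC)c3)nn2)c1` carries four methoxy groups, and in this assay compound 3 gives 10000 nM. Compound 2 `COc1ccc(-n2cc(-c3ccc(O)c(OC)c3)nn2)cc1O` has two free hydroxy groups beside its methoxy groups. In this assay compound 2 gives > 10000 nM, again a limit of the assay and not a number. Compound 2 therefore stands at the limit of > 10000 nM in this assay, at which 2 of the 3 values shown sit, and no numerical comparison with compound 1 or compound 3 is possible from these values.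

Compound 4 `COc1ccc(-n2cc(-c3ccc(OC)c(OC)c3)nn2)cc1O` is the next member and has not yet been measured in this assay. It differs from compound 2 by methyl in place of hydrogen on an oxygen on an aromatic ring. Among the measured compounds shown here, no step between measured compounds is available, so the expectation rests on the three values above, all of which sit at or near the same level. The step from compound 2 to compound 4 is estimated as a number no higher from compound 2 to compound 4 (the limit leaves the size open), with no change beyond the scatter expected. Compound 4 is accordingly expected to give about 10000 nM in this assay, within a range of 5000 nM to 30000 nM, and most likely reported as a limit.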

Compound 4, half-maximal inhibitory concentration: > 1000 nM
Compound 4: only a limit was reported; the forecaster's own chance of this, stated with the estimate: 70%; the middle value does not contradict the limit.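

In this assay compound 2 gives > 10000 nM, a limit of the assay and not a number. Compound 4 gives > 1000 nM, likewise a limit, so no step can be read between compound 2 and compound 4. The compounds shown leave open whether methyl in place of hydrogen on an oxygen on an aromatic ring changes the read-out in this assay at all.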